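The source may hold more compounds than are shown below. What is called first, only, known or untested is meant among the compounds shown, and "the series" means these compounds.

Measured so far:
compound 1 `CC1(COc2ccc(-c3ccc(C(F)(F)F)cc3)cc2)Cn2cc([N+](=O)[O-])nc2O1` — > 64000 nM
compound 2 `CC1(COc2ccc(-c3ccc(OC(F)(F)F)cc3)cc2)Cn2cc([N+](=O)[O-])nc2O1` — > 64000 nM
compound 3 `CC1(COc2ccc(-c3ccc(C(F)(F)F)cc3)nc2)Cn2cc([N+](=O)[O-])nc2O1` — > 64000 nM

All three values are limits of the assay, not numbers. In an ADME assay on MRC5 cells (Homo sapiens) for cytotoxicity, read by fluorescence, with a stated time of 72 h (on this read-out higher numbers stand for weaker inhibition and lower numbers for stronger inhibition), compound 1 reaches only the limit > 64000 nM. Compound 2 likewise gives only the limit > 64000 nM in this assay. Compound 3 also returns only the limit > 64000 nM.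

The change from compound 1 to compound 2 is trifluoromethoxy in place of trifluoromethyl on an aromatic carbon; the step it made, a step that the two limits leave unreadable from compound 1 to compound 2, cannot be sized because both values sit at the limit of > 64000 nM in this assay, at which 3 of the 3 values shown sit. The difference between the core of compound 1 and the core of compound 3 is not broken down here.

Compound 4 `CC1(COc2ccc(-c3ccc(OC(F)(F)F)cc3)nc2)Cn2cc([N+](=O)[O-])nc2O1` is not yet measured. It differs from compound 3 by trifluoromethoxy in place of trifluoromethyl on an aromatic carbon, the same change as from compound 1 to compound 2. Because both measured members of this change sit at the limit of > 64000 nM in this assay, at which 3 of the 3 values shown sit, the step from compound 3 to compound 4 is expected to be a step that the limit leaves unreadable from compound 3 to compound 4, with a number only if the limit is exceeded. Compound 4 is therefore expected at 100000 nM, most likely reported again as a limit of this assay.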

Compound 4, half-maximal inhibitory concentration: > 64000 nM
Compound 4: no number, only a limit; the forecaster's own chance of this, stated with the estimate: 90%; the middle value does not contradict the limit.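

No new step can be read between compound 3 and compound 4 in this assay, because both give only a limit and not a number: the limit of > 64000 nM in this assay, at which 4 of the 4 values shown sit.

The compounds shown leave open what number any of them would give in this assay, and so whether trifluoromethoxy in place of trifluoromethyl, or the difference between the core of compound 1 and the core of compound 3, has any effect there.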